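Swapping a phenylpiperazine for an isopentyloxy chain

This account rests on a few compounds, and the source may have more. Where it says the series, first, only, none or still open, it means among the compounds named here.

Of the compounds shown here, three sharing one core have been measured in an assay on cells for antagonist activity at transient receptor potential cation channel subfamily V member 1 (Homo sapiens), read by FLIPR and calcium flux, with a stated time of 6 min; a higher number here means a weaker inhibitor, a lower number a stronger inhibitor. Compound 3 `CC(C(=O)NCc1ccc(C(C)(C)C)cc1N1CCN(c2ccccc2)CC1)c1ccc(NS(C)(=O)=O)c(F)c1` gives 0.8 nM, the lowest number among the three. Compound 1 `CC(C(=O)NCc1ccc(C(C)(C)C)nc1OC1CCCC1)c1ccc(NS(C)(=O)=O)c(F)c1` gives 1.5 nM, which lies within the scatter of compound 3, so the two cannot be ranked. Compound 2 `CCOCCOc1nc(C(C)(C)C)ccc1CNC(=O)C(C)c1ccc(NS(C)(=O)=O)c(F)c1` gives 23.9 nM, well beyond the scatter from compound 3. Among the compounds with values here, the only step among measured compounds that differ in one place is a 16-fold higher number from compound 1 to compound 2 (1.20 log units; beyond the scatter); it shows that changing the group on the ring oxygen can move the number a great deal.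

Compound 4 `CC(C)CCOc1cc(C(C)(C)C)ccc1CNC(=O)C(C)c1ccc(NS(C)(=O)=O)c(F)c1` is an unmeasured compound derived from compound 3 by the change (isopentyloxy in place of 4-phenylpiperazin-1-yl on an aromatic carbon). Within the data shown here, no measured pair shows this particular swap, so only indirect guidance exists: compound 1, with a cyclic alkoxy group on its ring, sits close to compound 3, while compound 2, with an ether-containing chain, sits far away. An isopentyloxy group is a plain alkyl chain on oxygen, so compound 4 is expected to land nearer compound 1 than compound 2. The estimated step is a 3.1-fold higher number from compound 3 to compound 4 (0.49 log units; beyond the scatter), a modest rise. Compound 4 is therefore estimated at 2.5 nM, with a likely range from 0.7 nM to 9 nM.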

Compound 4, inhibition constant: 0.6 nM
Estimate against measurement, compound 4: 4.2-fold (0.62 log units) above, outside the stated range (below it).
By their numbers in this assay, from the lowest: compounds 4, 3 and 1 (each within the scatter of the next, the first and the last beyond it); then compound 2.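

In this assay, replacing 4-phenylpiperazin-1-yl with isopentyloxy on this aromatic carbon gives a 1.3-fold lower number from compound 3 to compound 4 (0.12 log units; within the scatter), so this pair cannot be ranked and the swap has no readable effect on the number. The position, which is ortho to a large group and meta to a tert-butyl group, therefore accepts two very different groups with no readable difference: one has 12 heavy atoms and two rings, and the other has 6 heavy atoms and no ring. For this pair, neither the ring system of the 4-phenylpiperazin-1-yl group nor its full size is needed to keep the number in the same range, and no measurement shown explains why the two groups read alike.

The compounds shown leave open how much of a group this position needs, since a much smaller group such as methoxy, or a bare hydroxyl, could show whether any substituent on this carbon matters at all. They also leave open whether a piperazine without its phenyl ring, or a longer chain than isopentyloxy, would stay in this same range.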